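The source may hold more compounds than are shown below. What is called first, only, known or untested is meant among the compounds shown, and "the series" means these compounds.

Measured compounds in the series:
compound 1 `CC(C)(C)C#Cc1cc(N(C(=O)[C@H]2CC[C@H](C)CC2)[C@H]2CC[C@@H](Oc3ccc(=O)[nH]n3)CC2)c(C(=O)O)s1` — > 20000 nM
compound 2 `CC(C)N(c1cc(C#CC(C)(C)C)sc1C(=O)O)C(=O)[C@H]1CC[C@H](Cl)CC1` — > 20000 nM

In an ADME assay on MT4 cells (Homo sapiens) for cytotoxicity, with a stated time of 5 days (on this read-out lower numbers stand for higher toxicity in this test and higher numbers for lower toxicity in this test), compound 1 gives > 20000 nM, which is a limit of the assay and not a number. Compound 2 gives > 20000 nM in this assay, again a limit rather than a measured number. Within the data shown here, compound 2 therefore stands at the limit of > 20000 nM in this assay, at which 2 of the 2 values shown sit; both values shown in this assay are limits, so no measured step exists and no order between compound 1 and compound 2 can be read from them.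

Compound 3 `CC(C)N(C(=O)C1CCCCCC1)c1cc(C#CC(C)(C)C)sc1C(=O)O` has not yet been measured in this assay. It differs from compound 2 in one place: cycloheptyl in place of 4-chlorocyclohexyl on a carbonyl carbon. The change leaves the carbonyl carbon and its amide-type nitrogen neighbour untouched and keeps the heavy-atom count of the departing and entering groups equal.

With both reference values sitting at the limit, the step from compound 2 to compound 3 is expected to be none beyond the scatter, that is a step that the limit leaves unreadable from compound 2 to compound 3, and the read-out is expected most likely to remain a limit. Compound 3 is accordingly estimated at 25000 nM in this assay, with a range from 10000 nM to 60000 nM.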

Compound 3, half-maximal cytotoxic concentration: > 20000 nM
Compound 3 ended at the assay's limit (the forecaster's own chance of this, stated with the estimate: 80%); the middle value does not contradict the limit.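

Compound 3 gives > 20000 nM in this assay, a limit of the assay and not a number. With compound 2 also at a limit, no step can be read between compound 2 and compound 3. Open, going by these compounds, is where the cytotoxic concentrations of compound 1, compound 2 and compound 3 lie, and whether they differ at all.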